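The source may report more compounds than this note shows. Statements on the series, on what has been measured and on what is new or still open speak of the compounds shown alone.

In a functional assay on MCF7 cells (Homo sapiens) for cytotoxicity, read by MTT assay, with stated times of 6 h and 48 h (on this read-out lower numbers stand for stronger inhibition and higher numbers for weaker inhibition), compound 2 (`Cn1c(/C=C/C(=O)c2ccccc2)cc(Br)c1Br`) gives 35400 nM, the highest number among the three measured compounds. Compound 1 (`Cn1c(/C=C/C(=O)c2ccccc2O)cc(Br)c1Br`) gives 2510 nM and compound 3 (`Cn1c(/C=C/C(=O)c2ccc[nH]2)cc(Br)c1Br`) gives 450 nM. Next is compound 4 (`Cn1c(/C=C/C(=O)c2cccc(O)c2)cc(Br)c1Br`), which differs from compound 2 by hydroxy in place of hydrogen on an aromatic carbon, meta to a large group.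

Within the data shown here, the closest precedent is the step that removes a hydroxy, a 14-fold higher number from compound 1 to compound 2 (1.15 log units; beyond the scatter), which is large and beyond the scatter. Read in reverse, it points to a lower number when hydroxy enters. Among the measured compounds shown here, the hydroxy of compound 1 stands elsewhere on the ring, however, and no measured compound carries it where compound 4 does. Going by these compounds, how much of that step carries over is unknown. The other step, a 79-fold lower number from compound 2 to compound 3 (1.90 log units; beyond the scatter), is also large but exchanges the whole phenyl, and it bears only weakly on this change.

A drop in this assay smaller than the hydroxy precedent is expected, an estimated 3.5-fold lower number from compound 2 to compound 4 (0.55 log units; beyond the scatter). Compound 4 is estimated at 10000 nM, with an expected range of 2500 nM to 32000 nM.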

Compound 4, half-maximal inhibitory concentration: 12800 nM
Compound 4: middle estimate off by 1.3-fold (0.11 log units), on the low side, within the range that was stated.
By their numbers in this assay, from the lowest: compound 3; then compound 1; then compound 4; then compound 2.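

In this series, hydroxy in place of hydrogen on an aromatic carbon, meta to a large group, lowers the number in this assay only modestly (a 2.8-fold lower number from compound 2 to compound 4 (0.44 log units; beyond the scatter)). Loss of the hydroxy of compound 1, which stands elsewhere on the ring, gives a larger change (a 14-fold higher number from compound 1 to compound 2 (1.15 log units; beyond the scatter)), so among these compounds the size of the hydroxy effect differs with its place. Nothing at hand explains that difference.

Still open, going by these compounds, is whether an amine, a methoxy group or a carboxylic acid at this same place would move the number as hydroxy does. Also open, on these data alone, is whether a hydroxy on the remaining ring position would follow compound 1 or compound 4.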